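Trimming an ethyl from a weak whole-organism inhibitor

The source may hold more compounds than are shown below. What is called first, only, known or untested is meant among the compounds shown, and "the series" means these compounds.

Compound 1 `Cc1nc(CC(C)(C)C)n2c(O)nncc12` gives > 48000 nM in a functional assay for inhibition, with Homo sapiens as the target (on this read-out lower numbers stand for stronger inhibition and higher numbers for weaker inhibition), a limit of the assay.
Compound 2 `CCc1nnc(O)n2c(CC)nc(C)c12` gives 24000 nM in this assay.

Within the data shown here, compound 2 holds the only actual number among the values shown. Compound 1 sits at a limit of the assay, (the limit of > 48000 nM in this assay, at which 1 of the 2 values shown sits). Compound 3 `CCc1nc(C)c2cnnc(O)n12` differs from compound 2 by hydrogen in place of ethyl on an aromatic carbon. Among the measured compounds shown here, no two measured compounds differ in only one place, so no measured step sets a scale for this change. For compound 3 the step of a 1.5-fold higher number from compound 2 to compound 3 (0.16 log units; within the scatter) is expected to be small, within the usual scatter or leaning slightly toward weaker inhibition. Compound 3 is therefore estimated at 35000 nM, in the range 12000 nM to 96000 nM, with a fair chance that only a limit is reported.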

Compound 3, half-maximal inhibitory concentration: > 48000 nM
Compound 3: only a limit was reported (the forecaster's own chance of this, stated with the estimate: 35%); middle value at least 1.3-fold (0.13 log units) away from the limit.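

Among these compounds, putting hydrogen in place of ethyl on this aromatic carbon gives an at least 2.0-fold higher number from compound 2 to compound 3 (0.30 log units; that floor lies within the scatter) in this assay, the first readable step between two measured compounds. Its floor lies within the scatter, so weaker inhibition on losing the ethyl is not established, though no gain in inhibition appears. Because compound 3 gives only a limit, the full size of this step is unknown, and the step from compound 1 to compound 3 cannot be read: the limit of > 48000 nM in this assay, at which 2 of the 3 values shown sit.

From the compounds shown here alone, whether a propyl chain or an amine on this aromatic carbon would give stronger inhibition stays open. So does whether any such group would bring a measured number rather than a limit.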